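Trading methyl for trifluoromethyl at the edge of measurement

The source may hold more compounds than are shown below. What is called first, only, known or untested is meant among the compounds shown, and "the series" means these compounds.

In a functional assay on HCT-15 cells (Homo sapiens) for cytotoxicity, read by MTT assay, with a stated time of 2 days (on this read-out lower numbers stand for stronger inhibition and higher numbers for weaker inhibition), compound 1 `Cc1cccc(-c2nc3ccc(C)cc3c(=O)[nH]2)c1` gives > 50000 nM, and this figure is a limit of the assay, not a number. On these data alone, that places compound 1 at the limit of > 50000 nM in this assay, at which 1 of the 2 values shown sits, so its true strength remains unknown.

In this assay compound 2 `Cc1ccc2c(=O)[nH]c(-c3ccccc3OC(F)(F)F)nc2c1` gives an actual number, 15900 nM. For the measured compounds named here, no measured pair here differs in one place only, so the data give no direct size for a single change.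

Compound 3 `Cc1ccc2nc(-c3cccc(C(F)(F)F)c3)[nH]c(=O)c2c1` has trifluoromethyl in place of methyl on an aromatic carbon, on a six-membered aromatic ring of carbon only, meta to a large group (trifluoromethyl in place of methyl on an aromatic carbon).

Compound 2 at 15900 nM shows that a closely similar structure can give a number, so a modest move towards stronger inhibition seems a reasonable expectation, though not a large one. The expected change is an at least 1.6-fold lower number from compound 1 to compound 3 (0.22 log units; that floor lies within the scatter), and the reading may still end up as a limit. For compound 3 the estimated value is 30000 nM, with an expected range from 12000 nM to 60000 nM.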

Compound 3, half-maximal inhibitory concentration: > 50000 nM
Compound 3: only a limit was reported; the forecaster's own chance of this, stated with the estimate: 45%; at least 1.6-fold (0.22 log units) between middle value and limit.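

In this assay, compound 1 and compound 3 both end at a limit rather than a number, so the step between them cannot be read: the limit of > 50000 nM in this assay, at which 2 of the 3 values shown sit.

The compounds shown leave open how strongly either one really inhibits, and whether trifluoromethyl in place of methyl on an aromatic carbon changes that at all.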